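Swapping tert-Butyl for Ethoxy: What Solubility to Expect

This account rests on a few compounds, and the source may have more. Where it says the series, first, only, none or still open, it means among the compounds named here.

Measured so far:
compound 1 `C[C@]1(COc2ccc(S(=O)(=O)N3CCOCC3)cc2)Cn2cc([N+](=O)[O-])nc2O1` gives 20 ug/mL
compound 2 `CC(C)(C)c1ccc(NC(=O)Nc2ccc(OC[C@@]3(C)Cn4cc([N+](=O)[O-])nc4O3)cc2)cc1` gives < 1 ug/mL, a limit of the assay rather than a number
compound 3 `C[C@]1(COc2ccc(-n3cc(COc4ccc(OC(F)(F)F)cc4)nn3)cc2)Cn2cc([N+](=O)[O-])nc2O1` gives < 1 ug/mL, also a limit of the assay

All three were measured in a physicochemical assay for solubility, read by HPLC, with a stated time of 4 h, at pH 7; on this read-out higher numbers stand for higher solubility and lower numbers for lower solubility. Compound 1 is the only one with a numeric result. Compound 2 sits at the limit, as does compound 3, which is the limit of < 1 ug/mL in this assay, at which 2 of the 3 values shown sit. Compound 2 therefore stands at the bottom of what the numbers show, with no true value known, only a ceiling.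

The untested compound 4 `CCOc1ccc(NC(=O)Nc2ccc(OC[C@@]3(C)Cn4cc([N+](=O)[O-])nc4O3)cc2)cc1` differs from compound 2 in one place: ethoxy in place of tert-butyl on an aromatic carbon. Going by the values given here, no measured pair in this set shows the effect of such a swap, so there is no recorded step to lean on. The expectation is a small move in this assay, probably upward from the limit but not far, and possibly no move beyond the usual scatter at all. On that basis compound 4 is expected to give 2 ug/mL, between 0.5 ug/mL and 8 ug/mL, a step of an at least 2.0-fold higher number from compound 2 to compound 4 (0.30 log units; that floor lies within the scatter).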

Compound 4, solubility: 6.66 ug/mL
Beside the measured number, compound 4's estimate is 3.3-fold (0.52 log units) below it; low and high end bracket the measured number.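

Ethoxy in place of tert-butyl, on an aromatic carbon para to a large group, is the first single change in this set that can be read, and in this assay it comes out as an at least 6.6-fold higher number from compound 2 to compound 4 (0.82 log units; beyond the scatter). That step lies beyond the scatter, so the group at this place on the ring does matter for this read-out. Its full size remains unknown because the starting point is only a ceiling: the limit of < 1 ug/mL in this assay, at which 2 of the 4 values shown sit.

Compound 1 and compound 3 differ from these two in more than one place, so they cannot show whether the same swap would give a similar step elsewhere. As far as these compounds go, how an amine, a carboxylic acid or a longer chain such as butoxy would read at this place also remains open.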